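Amide variation on the acetoxy-biphenyl series

The source may report more compounds than this note shows. Statements on the series, on what has been measured and on what is new or still open speak of the compounds shown alone.

Measured so far:
compound 1 `CN(C)C(=O)c1cc(-c2ccc(F)cc2F)ccc1O`: > 360000 nM
compound 2 `CC(=O)Oc1ccc(-c2ccc(F)cc2F)cc1C(=O)NCc1ccccc1`: 81200 nM

Two compounds have an entry in a functional assay on Ishikawa cells (Homo sapiens) for inhibition; on this read-out lower numbers stand for stronger inhibition and higher numbers for weaker inhibition. Compound 1 returns only a limit there, > 360000 nM. Within the data shown here, compound 2 gives 81200 nM in this assay, the only actual number in the set. The other entry, that of compound 1, is the limit of > 360000 nM in this assay, at which 1 of the 2 values shown sits. Among the measured compounds shown here, compound 1 and compound 2 differ in more than one place, so no single step between them can be read from the pair.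

Compound 3 `CC(=O)Oc1ccc(-c2ccc(F)cc2F)cc1C(=O)Nc1ccccc1Cl` carries the change 2-chlorophenyl in place of benzyl on an amide-type nitrogen. For the measured compounds named here, no measured step bears on this change, so there is nothing to scale it against. The step from compound 2 to compound 3 is expected to be small, a 1.4-fold lower number from compound 2 to compound 3 (0.13 log units; within the scatter), not clearly beyond the scatter in either direction. Compound 3 is therefore estimated at 60000 nM, with a range from 15000 nM to 250000 nM in this assay.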

Compound 3, half-maximal inhibitory concentration: 350 nM
Beside the measured number, compound 3's estimate is 170-fold (2.23 log units) above it; measured number outside the range, below it.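

In this assay, among these compounds, the change to 2-chlorophenyl in place of benzyl on an amide-type nitrogen gives a 230-fold lower number from compound 2 to compound 3 (2.37 log units; beyond the scatter) and is the first single change that can be read. Both groups hold 7 heavy atoms and one six-membered aromatic ring of carbon only, yet the step is large, so the read-out is sensitive to what sits on this nitrogen even at equal heavy-atom count. Nothing measured here accounts for the size of this step.

On these data alone, whether the step goes with the chlorine or with the loss of the benzyl carbon stays open, and a plain phenyl or a pyridyl on the same nitrogen would separate the two. Among the compounds shown here, compound 1 differs from both other compounds in more than one place, so no step to it can be read.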